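Moving the fluorine and swapping halogens on the aryl ring

The source may hold more compounds than are shown below. What is called first, only, known or untested is meant among the compounds shown, and "the series" means these compounds.

In a functional assay on HepG2 cells (Homo sapiens) for cytotoxicity, read by MTT assay, with a stated time of 72 h (on this read-out lower numbers stand for stronger inhibition and higher numbers for weaker inhibition), compound 2 `O=C(Nc1ccc(Oc2ccnc3[nH]ccc23)cc1)c1nn(-c2ccc(Br)cc2F)ccc1=O` gives 46400 nM, the highest of the two numbers; compound 1 `O=C(Nc1ccc(Oc2ccnc3[nH]ccc23)cc1)c1nn(-c2ccc(Br)cc2)ccc1=O` gives 4280 nM. For the measured compounds named here, the only comparable step is an 11-fold higher number from compound 1 to compound 2 (1.04 log units; beyond the scatter). Compound 3 `O=C(Nc1ccc(Oc2ccnc3[nH]ccc23)cc1)c1nn(-c2ccc(Cl)c(F)c2)ccc1=O` carries 4-chloro-3-fluorophenyl in place of 4-bromo-2-fluorophenyl on an aromatic nitrogen. Going by the values given here, that removes the added fluorine of compound 2, but the new fluorine position and the chlorine have no measured counterpart. Compound 3 is therefore expected to land between the two measured values, a step of a 3.9-fold lower number from compound 2 to compound 3 (0.59 log units; beyond the scatter). The estimate for compound 3 is 12000 nM, with a range from 3000 nM to 45000 nM.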

Compound 3, half-maximal inhibitory concentration: 5240 nM
Compound 3: middle estimate off by 2.3-fold (0.36 log units), on the high side; measured number inside the range.
By their numbers in this assay, from the lowest: compounds 1 and 3 (each within the scatter of the next); then compound 2.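

In this assay, 4-chloro-3-fluorophenyl in place of 4-bromo-2-fluorophenyl recovers most of the earlier loss, with an 8.9-fold lower number from compound 2 to compound 3 (0.95 log units; beyond the scatter). A fluorine on this aryl ring therefore does not by itself bring the high number, as the step against the unfluorinated ring is only a 1.2-fold higher number from compound 1 to compound 3 (0.09 log units; within the scatter). No evidence is at hand to explain these steps. As far as these compounds go, the fluorine position and the swap of bromine for chlorine change together here, so their separate shares stay open. From the compounds shown here alone, how an amine or a methoxy group on this ring would read also remains open.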